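Fluoro on the benzamide ring of compound 3

The source may report more compounds than this note shows. Statements on the series, on what has been measured and on what is new or still open speak of the compounds shown alone.

Of the compounds shown here, three sharing one core have been measured in a functional assay on SK-MEL-5 cells (Homo sapiens) for antiproliferative activity; on this read-out lower numbers stand for stronger inhibition of growth and higher numbers for weaker inhibition of growth. Compound 1 `COc1cccc(-c2nn(-c3ccccc3)cc2-c2ccnc(NCCCNC(=O)c3cccc(C(F)(F)F)c3)c2)c1` gives 1540 nM in this assay. Among the measured compounds shown here, compound 2 `COc1cccc(-c2nn(-c3ccccc3)cc2-c2ccnc(NCCCNC(=O)Nc3ccc(Cl)c(Cl)c3)c2)c1` gives 1750 nM in this assay, and the only single-point step among the measured compounds, a 1.1-fold higher number from compound 1 to compound 2 (0.06 log units; within the scatter), stays within the scatter. Compound 3 `O=C(NCCCNc1cc(-c2cn(-c3ccccc3)nc2-c2cccc(O)c2)ccn1)c1ccccc1` gives 1490 nM in this assay; its number is the smallest of the three as read, but it lies within the scatter of both compound 1 and compound 2, so no order among them can be claimed.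

Compound 4 `O=C(NCCCNc1cc(-c2cn(-c3ccccc3)nc2-c2cccc(O)c2)ccn1)c1ccc(F)cc1` differs from compound 3 by fluoro in place of hydrogen on an aromatic carbon, that is, phenyl to 4-fluorophenyl on the benzoyl group. For the measured compounds named here, no measured step touches this position; the one step known exchanges a whole aryl tail and was within the scatter. For compound 4 the step of a 1.1-fold lower number from compound 3 to compound 4 (0.03 log units; within the scatter) is therefore expected to be small, without a clear direction. Compound 4 is estimated at 1400 nM in this assay, with a range from 600 nM to 3300 nM.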

Compound 4, concentration for 50% growth inhibition: 1610 nM
Compound 4: the middle estimate sits 1.2-fold (0.06 log units) below what was measured, and the stated range covers the measured number.
By their numbers in this assay, from the lowest: compounds 3, 1, 4 and 2 (each within the scatter of the next).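

Fluoro in place of hydrogen on the benzoyl ring gives the only step shown at this position, and in this assay it reads a 1.1-fold higher number from compound 3 to compound 4 (0.03 log units; within the scatter). Phenyl and 4-fluorophenyl therefore cannot be told apart on this read-out. The earlier step had exchanged a whole aryl tail, whereas this one adds a single heavy atom to the simple benzamide, and it too stays within the scatter. Nothing available offers an explanation for this result.

As far as these compounds go, whether this holds for the position as a whole stays open, since an amine, a carboxylic acid or a methoxy group on the same ring might read differently from fluoro. Equally open, from the compounds shown here alone, is how a longer chain in place of the linker of compound 3 would read.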